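A Methyl to Hydrogen Step on Compound 2

This account rests on a few compounds, and the source may have more. Where it says the series, first, only, none or still open, it means among the compounds named here.

Compound 1 `CC1(C)C/C(=N\OC(=O)c2cccc(NC(=O)c3cccc(F)c3)c2)c2c(noc2-c2cccc(F)c2)C1` and compound 2 `COc1ccc(-c2onc3c2/C(=N/OC(=O)c2cccc(NC(=O)c4cccc(F)c4)c2)CC(C)(C)C3)cc1OC` share one core and differ only in the aryl group on an aromatic carbon, 3,4-dimethoxyphenyl in place of 3-fluorophenyl. In a functional assay on HCC1954 cells (Homo sapiens) for antiproliferative activity, read by MTT assay, with a stated time of 72 h (a higher number here means a weaker inhibitor, a lower number a stronger inhibitor), compound 1 gives > 25000 nM, which is a limit of the assay and not a number. In this assay compound 2 gives > 25000 nM, again a limit of the assay and not a number. The step that the two limits leave unreadable from compound 1 to compound 2 therefore cannot be read, and compound 2 stands at the limit of > 25000 nM in this assay, at which 2 of the 2 values shown sit. Compound 3 `COc1cc(-c2onc3c2/C(=N/OC(=O)c2cccc(NC(=O)c4cccc(F)c4)c2)CC(C)(C)C3)ccc1O` differs from compound 2 by hydrogen in place of methyl on an oxygen on an aromatic ring. No measured step bears on this change, and the one step shown is itself unreadable, so the numbers give no size or direction to expect in this assay. Compound 3 is therefore estimated at 30000 nM, with a range from 8000 nM to 100000 nM. The step that the limit leaves unreadable from compound 2 to compound 3 is expected to stay within the scatter.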

Compound 3, half-maximal inhibitory concentration: 6000 nM
Beside the measured number, compound 3's estimate is 5.0-fold (0.70 log units) above it, outside the stated range (below it).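

Hydrogen in place of methyl on an oxygen on an aromatic ring gives, in this assay, an at least 4.1-fold lower number from compound 2 to compound 3 (0.61 log units; beyond the scatter), the first step in this set that can be read. The change from 3-fluorophenyl to 4-hydroxy-3-methoxyphenyl on the aromatic carbon gives an at least 4.1-fold lower number from compound 1 to compound 3 (0.61 log units; beyond the scatter), so the aryl group at this place does bear on the read-out, which the earlier step between two limits could not show. Compound 3 is the only one of the three with a number and not a limit: the limit of > 25000 nM in this assay, at which 2 of the 3 values shown sit.

Going by these compounds, both steps rest on a limit, so their full size stays open. On these data alone, it also stays open what an amine or a carboxylic acid would give in place of the hydroxy on this ring, and whether a second hydroxy in place of the remaining methoxy would move the value further.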